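Pyrazole nitrogen substituent swap in a dichlorophenylsulfonamide series

The source may report more compounds than this note shows. Statements on the series, on what has been measured and on what is new or still open speak of the compounds shown alone.

Measured so far in a functional assay on cells for antagonist activity at C-C chemokine receptor type 4 (Homo sapiens), read by GTPgammaS binding; on this read-out lower numbers stand for stronger inhibition and higher numbers for weaker inhibition:
- compound 1, `COc1nn(C)c2cccc(NS(=O)(=O)c3cccc(Cl)c3Cl)c12`: 794 nM
- compound 2, `CCn1[nH]c2ncnc(NS(=O)(=O)c3cccc(Cl)c3Cl)c2c1=O`: compound 2 gives only a limit, > 31600 nM
- compound 3, `COc1nn(C(C)C)c2ncnc(NS(=O)(=O)c3cccc(Cl)c3Cl)c12`: 251 nM

Three dichlorophenylsulfonamides on three different bicyclic cores. Compound 3 holds the lowest of the two numbers given; compound 1 sits at a number that is beyond the scatter above it. The value for compound 2 is a limit of this assay and not a number (the limit of > 31600 nM in this assay, at which 1 of the 3 values shown sits), so it cannot be placed against the other two.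

The next compound, compound 4, is `CNC(=O)Cn1nc(OC)c2c(NS(=O)(=O)c3cccc(Cl)c3Cl)ncnc21`. It keeps the core of compound 3 and changes only the group on the aromatic nitrogen: (methylcarbamoyl)methyl in place of isopropyl on an aromatic nitrogen.

Among the measured compounds shown here, no measured pair in the set differs at this position alone, so the size of the step has no precedent here. The expectation is that the step of a 2.4-fold higher number from compound 3 to compound 4 (0.38 log units; beyond the scatter) leads to a somewhat weaker result than compound 3, though the range kept is wide enough to include a result within the scatter of compound 3. For compound 4 in this assay the estimate is 600 nM, between 120 nM and 3000 nM.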

Compound 4, half-maximal inhibitory concentration: 631 nM
For compound 4 the middle estimate is 1.1-fold (0.02 log units) below the measured one; the measured number falls inside the stated range.
By their numbers in this assay, from the lowest: compound 3; then compounds 4 and 1 (each within the scatter of the next). At a limit, above all of these: compound 2.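

In this assay, among the compounds shown here, this is the first reading of a change at the aromatic nitrogen on the core of compound 3: (methylcarbamoyl)methyl in place of isopropyl gives a 2.5-fold higher number from compound 3 to compound 4 (0.40 log units; beyond the scatter) as a modest step. The position therefore takes a longer substituent with a hydrogen-bond donor and a hydrogen-bond acceptor, neither of which isopropyl has, and compound 4 still gives a measured 631 nM rather than a limit of the assay. Nothing measured in this set accounts for the size of this step.

With a single step at this position, the amide hydrogen, the carbonyl and the added chain length cannot be told apart as sources of the change. Going by these compounds, a plain n-propyl or n-butyl chain, the corresponding N,N-dimethylamide, a carboxylic acid or a primary amine on the same core would each separate these parts, and whether any group here can match or improve on isopropyl stays open.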